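This account rests on a few compounds, and the source may have more. Where it says the series, first, only, none or still open, it means among the compounds named here.

In an assay on CHO cells for displacement of a labelled ligand from adenosine receptor A1 (Homo sapiens), read by scintillation counting, with a stated time of 3 h (a lower number here means a stronger inhibitor, a higher number a weaker inhibitor), compound 3 `CC(C)n1cc2c(Cl)nc(NC(=O)c3ccc(F)cc3)nc2n1` gives 3400 nM, the lowest of the three numbers recorded so far. Compound 1 `Cc1ccc(C(=O)Nc2nc(Cl)c3cn(CC(C)(C)C)nc3n2)cc1` gives 11100 nM in this assay, and compound 2 `CC(C)(C)Cn1cc2c(Cl)nc(NC(=O)c3ccccc3)nc2n1` gives 11000 nM; the step of a 1.0-fold lower number from compound 1 to compound 2 (0.00 log units; within the scatter) shows that the change on the amide aryl did not move the number. Compound 4 `CC(C)(C)Cn1cc2c(Cl)nc(NC(=O)c3ccc(F)cc3)nc2n1` differs from compound 3 by neopentyl in place of isopropyl on an aromatic nitrogen. Among the measured compounds shown here, no measured step covers this exchange. Still, compound 1 and compound 2 both carry the neopentyl group, and their numbers in this assay sit well above that of compound 3, so a weakening step is expected: a 2.4-fold higher number from compound 3 to compound 4 (0.37 log units; beyond the scatter). Compound 4 is therefore estimated at 8000 nM in this assay, within a range from 3000 nM to 20000 nM.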

Compound 4, inhibition constant: 16500 nM
Estimate against measurement, compound 4: 2.1-fold (0.31 log units) below; the range from low to high includes it.
By their numbers in this assay, from the lowest: compound 3; then compounds 2, 1 and 4 (each within the scatter of the next).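

In this assay, among the compounds shown here, neopentyl in place of isopropyl on the aromatic nitrogen gives a 4.9-fold higher number from compound 3 to compound 4 (0.69 log units; beyond the scatter), the first direct reading of this exchange, and it lies beyond the scatter. With neopentyl held there, the changes on the amide aryl stay within the scatter: fluoro in place of hydrogen gives a 1.5-fold higher number from compound 2 to compound 4 (0.18 log units; within the scatter), and fluoro in place of methyl gives a 1.5-fold higher number from compound 1 to compound 4 (0.17 log units; within the scatter). No evidence is available on why the group on this nitrogen matters. Still open, from the compounds shown here alone, is how a cyclopropyl group or a longer chain on this nitrogen would read, and whether the amide aryl changes would stay within the scatter with isopropyl there.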